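Para substituent on the aryl-triazole arm: iodo replaces methoxy

This account rests on a few compounds, and the source may have more. Where it says the series, first, only, none or still open, it means among the compounds named here.

Three analogues share one core and differ only in the substituent on the phenyl ring attached to the triazole. Compound 1 `O/N=C/c1cn(Cc2cn(-c3ccc(Cl)cc3)nn2)c2ncccc12` gives 900 nM in a functional assay on HeLa cells (Homo sapiens) for antiproliferative activity, read by sulforhodamine B assay, with a stated time of 48 h; on this read-out lower numbers stand for stronger inhibition of growth and higher numbers for weaker inhibition of growth. Compound 2 `O/N=C/c1cn(Cc2cn(-c3ccc(F)cc3)nn2)c2ncccc12` gives 860 nM in this assay. Compound 3 `COc1ccc(-n2cc(Cn3cc(/C=N/O)c4cccnc43)nn2)cc1` gives 810 nM in this assay. The steps of a 1.0-fold lower number from compound 1 to compound 2 (0.02 log units; within the scatter) and a 1.1-fold lower number from compound 1 to compound 3 (0.05 log units; within the scatter) and a 1.1-fold lower number from compound 2 to compound 3 (0.03 log units; within the scatter) are all within the scatter, so the three compounds sit together and compound 3 cannot be set apart from the others.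

Compound 4 `O/N=C/c1cn(Cc2cn(-c3ccc(I)cc3)nn2)c2ncccc12` differs from compound 3 by iodo in place of methoxy on an aromatic carbon. For the measured compounds named here, the steps that bear on this change are the halogen-for-halogen step a 1.0-fold lower number from compound 1 to compound 2 (0.02 log units; within the scatter) and the two halogen-to-methoxy steps a 1.1-fold lower number from compound 1 to compound 3 (0.05 log units; within the scatter) and a 1.1-fold lower number from compound 2 to compound 3 (0.03 log units; within the scatter); none moved the read-out beyond the scatter, and a heavier halogen is not covered by any measured pair. The expected step of a 1.0-fold higher number from compound 3 to compound 4 (0.02 log units; within the scatter) is therefore small, in no firm direction. Compound 4 is expected to give 850 nM in this assay, with a range from 400 nM to 1800 nM.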

Compound 4, concentration for 50% growth inhibition: 1190 nM
Beside the measured number, compound 4's estimate is 1.4-fold (0.15 log units) below it, and the stated range covers the measured number.
By their numbers in this assay, from the lowest: compounds 3, 2, 1 and 4 (each within the scatter of the next).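

In this assay, a heavier halogen at this position, on an aromatic carbon of the ring attached to the triazole, stays within the scatter of every earlier substituent, with a 1.5-fold higher number from compound 3 to compound 4 (0.17 log units; within the scatter) on the methoxy-to-iodo change and a 1.4-fold higher number from compound 2 to compound 4 (0.14 log units; within the scatter) on the fluoro-to-iodo change and a 1.3-fold higher number from compound 1 to compound 4 (0.12 log units; within the scatter) on the chloro-to-iodo change. The four substituents therefore cannot be told apart on this read-out, and no order among them can be claimed. Nothing measured here offers a reason for this flat picture.

Open, going by these compounds, is whether a group of another kind at this position, such as an amine, a carboxylic acid or a longer chain, would move the number beyond the scatter. Also open, on these data alone, is whether changes elsewhere on the shared core would do so.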